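Methyl in Place of Hydrogen at Two Different Places

The source may report more compounds than this note shows. Statements on the series, on what has been measured and on what is new or still open speak of the compounds shown alone.

Three compounds have been measured in an assay on blood for inhibition of C-X-C chemokine receptor type 3 (Homo sapiens), with a stated time of 30 min; a lower number here means a stronger inhibitor, a higher number a weaker inhibitor:
compound 1, `C[C@@H]1CN(c2scnc2-c2nc3ccccc3[nH]2)CCN1C(=O)Cn1cnc2cccnc21`, gives 554 nM;
compound 2, `CC[C@@H]1CN(c2scnc2-c2nc3ccccc3[nH]2)CCN1C(=O)Cn1cnc2cccnc21`, gives 851 nM;
compound 3, `COc1ccc(-c2nc(C(F)(F)F)sc2N2CCN(C(=O)Cn3nc(C)nc3C)[C@H](C)C2)cn1`, gives 1580 nM.

Compound 1 and compound 2 share one core, and they differ by methyl in place of hydrogen on a saturated chain carbon bound to a saturated ring carbon. That step is a 1.5-fold higher number from compound 1 to compound 2 (0.19 log units; within the scatter), so the two numbers cannot be told apart with confidence. Compound 3 is built on a different core, carrying a trifluoromethyl group and a 6-methoxypyridin-3-yl group; the difference between the two cores is not broken down here. Its value stands beyond the scatter from compound 1 but within the scatter of compound 2.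

Compound 4, `CCOc1ccc(-c2nc(C(F)(F)F)sc2N2CCN(C(=O)Cn3nc(C)nc3C)[C@H](C)C2)cn1`, has not been measured. It differs from compound 3 by methyl in place of hydrogen on a saturated chain carbon bound to an oxygen on an aromatic ring. Among the measured compounds shown here, this is the same kind of change as the one from compound 1 to compound 2, but not the same: there the added methyl sits on a saturated chain carbon bound to a saturated ring carbon, here on a saturated chain carbon bound to an oxygen on an aromatic ring, and the cores differ as well. For the measured compounds named here, the only guide is the single measured step, which was small. For compound 4 the expected step in this assay is a 1.3-fold higher number from compound 3 to compound 4 (0.10 log units; within the scatter), resting on compound 1 to compound 2 showing a 1.5-fold higher number from compound 1 to compound 2 (0.19 log units; within the scatter). Compound 4 is therefore estimated at 2000 nM, with a plausible range from 800 nM to 5000 nM, the range kept wide because the surroundings of the change differ from the measured case.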

Compound 4, half-maximal inhibitory concentration: 887 nM
The estimate for compound 4 lay 2.3-fold (0.35 log units) above the measured number, and the stated range covers the measured number.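

In this assay, turning the methoxy group of compound 3 into the ethoxy group of compound 4 gives a 1.8-fold lower number from compound 3 to compound 4 (0.25 log units; within the scatter), so the two numbers cannot be told apart with confidence. Taken alone, each methyl step is small, but set side by side the two steps do not agree, which means the effect of this change did not carry over unaltered from one core to the other: the same change on two cores in this assay, a 1.5-fold higher number (0.19 log units; within the scatter) from compound 1 to compound 2 and a 1.8-fold lower number (0.25 log units; within the scatter) from compound 3 to compound 4, 2.7-fold (0.44 log units) apart, beyond the scatter of two such steps. Among the compounds shown here, this does not show what sets the two steps apart, since the added methyl stands at a different place in each pair as well as on a different core, and each core offers only one pair, so neither the core nor the place can be singled out, and no general rule for adding a methyl follows.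

The compounds shown leave open how far the trend on the core of compound 3 runs, for instance whether a longer chain such as propoxy, or a branched one such as isopropoxy, would give a number that clearly separates from the methoxy and ethoxy pair. They also leave open how an amine or a hydroxyl group in place of the ethoxy group would read in this assay.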